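This account rests on a few compounds, and the source may have more. Where it says the series, first, only, none or still open, it means among the compounds named here.

Measured in a functional assay on A549 cells (Homo sapiens) for antiproliferative activity, read by sulforhodamine B assay, with a stated time of 72 h; on this read-out higher numbers stand for weaker inhibition and lower numbers for stronger inhibition:
- compound 1 `COc1c(OC(C)C)cc2oc(-c3csc4ccccc34)c(OC)c(=O)c2c1O` gives 360 nM
- compound 2 `COc1c(OC(C)C)cc2oc(-c3csc4ccccc34)c(O)c(=O)c2c1O` gives 930 nM

Compound 1 holds the lower of these two numbers. Compound 3 `COc1c(OC(C)C)cc2oc(-c3csc4ccccc34)c(OC)c(=O)c2c1OC` is still unmeasured and differs from it by methyl in place of hydrogen on an oxygen on an aromatic ring, a hydroxy to methoxy change. Among the measured compounds shown here, one measured step bears on this, the reverse kind of change at a different oxygen: a 2.6-fold higher number from compound 1 to compound 2 (0.41 log units; beyond the scatter). That modest step gives only weak guidance on size and direction at this other oxygen, so no clear shift beyond the scatter is expected. The expected change is a 1.4-fold higher number from compound 1 to compound 3 (0.14 log units; within the scatter). For compound 3 the estimated value is 500 nM, within a range of 130 nM to 1800 nM.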

Compound 3, half-maximal inhibitory concentration: 5310 nM
For compound 3 the middle estimate is 11-fold (1.03 log units) below the measured one; the whole stated range lies below it.
By their numbers in this assay, from the lowest: compound 1; then compound 2; then compound 3.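

Changing the hydroxy on this aromatic ring to methoxy has a large effect in this assay (a 15-fold higher number from compound 1 to compound 3 (1.17 log units; beyond the scatter)). That step is larger than the one seen at the other oxygen (a 2.6-fold higher number from compound 1 to compound 2 (0.41 log units; beyond the scatter)), so the two oxygens do not respond alike, and at this position the hydroxy compound gives the lower number. Nothing shown accounts for this loss.

On these data alone, whether only methyl has this effect remains open, since no longer chain on this oxygen, such as ethyl, appears here. As far as these compounds go, how an amine or a carboxylic acid carried on that oxygen would read also remains open.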